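The compounds below may be only part of what the source reports. "The series", "measured", "known", "first", "only" and "open" are said of these compounds alone.

Measured compounds:
Compound 1 `CNC(=O)c1cc(Oc2ccc(NC(=O)c3cc(-c4ccc(Br)cc4)ncn3)cc2)ccn1`: > 100000 nM
Compound 2 `CNC(=O)c1cc(Oc2ccc(NC(=O)c3nccc(-c4ccc(OC)cc4)n3)cc2F)ccn1`: 24300 nM
Compound 3 `CNC(=O)c1cc(Oc2ccc(NC(=O)c3cc(-c4ccc(Br)cc4)ncn3)cc2F)ccn1`: > 100000 nM

All three were tested in a functional assay on PC-3 cells (Homo sapiens) for cytotoxicity, read by MTT assay, with a stated time of 72 h; on this read-out lower numbers stand for stronger inhibition and higher numbers for weaker inhibition. In this assay, among the measured compounds shown here, compound 2 gives 24300 nM, the only actual number among the three. Compound 3 reaches only > 100000 nM, which is a limit of the assay rather than a number. Compound 1 likewise reaches only > 100000 nM, again a limit. Because the limit of > 100000 nM in this assay, at which 2 of the 3 values shown sit, describes where two of the three values sit, the step from compound 3 to compound 1, a step that the two limits leave unreadable from compound 3 to compound 1, cannot be read from the data.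

The change behind that step is hydrogen in place of fluoro on an aromatic carbon. The cores of compound 2 and compound 3 differ as well, but the difference between the two cores is not broken down here.

The compound not yet measured is compound 4 `CNC(=O)c1cc(Oc2ccc(NC(=O)c3nccc(-c4ccc(OC)cc4)n3)cc2)ccn1`. It differs from compound 2 by hydrogen in place of fluoro on an aromatic carbon, the same change as the one from compound 3 to compound 1, which occurs twice among these compounds. Since the step from compound 3 to compound 1 is unreadable, nothing measured shows how large this change is. Removing a single fluorine is a small alteration, so for compound 4 the expected step from compound 2 is a 1.0-fold higher number from compound 2 to compound 4 (0.01 log units; within the scatter), a step estimated to lie within the usual scatter. On that basis compound 4 is expected to give about 25000 nM in this assay, estimated to fall between 8000 nM and 80000 nM.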

Compound 4, half-maximal inhibitory concentration: 14200 nM
Estimate against measurement, compound 4: 1.8-fold (0.25 log units) above, and the stated range covers the measured number.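

In this assay, putting hydrogen in place of fluoro on the aromatic carbon gives a 1.7-fold lower number from compound 2 to compound 4 (0.23 log units; within the scatter), so on this core the change makes no difference that can be told apart from repeat-to-repeat variation. Among the compounds shown here, on the other core, the one shared by compound 3 and compound 1, the same change cannot be read, since both compounds sit at a limit of the assay and not at a number: the limit of > 100000 nM in this assay, at which 2 of the 4 values shown sit. For the compounds shown here, the series therefore holds only one readable example of this change, which shows what it does on one core but does not show that the result carries over to the other, where a similarly small step, a large one or any other outcome would fit the data equally well.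

The compounds shown leave open what a group other than fluoro or hydrogen, such as a nitrile or an amine, would do on that same aromatic carbon. They also leave open whether a compound on the core of compound 3, carrying for instance a carboxylic acid in place of the bromo group, would give a real number, which would let the change be compared across the two cores.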